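Benzylamide series: methoxy removal on the benzyl ring

The source may hold more compounds than are shown below. What is called first, only, known or untested is meant among the compounds shown, and "the series" means these compounds.

Measured compounds in a functional assay on Huh-7 cells (Homo sapiens) for inhibition, read by MTT assay, with a stated time of 48 h; a higher number here means a weaker inhibitor, a lower number a stronger inhibitor:
- compound 1 `COc1ccc2c(=O)c(/C=C/C(=O)Nc3cccc(C)c3)coc2c1` gives 15500 nM.
- compound 2 `COc1ccc2c(=O)c(/C=C/C(=O)Nc3cccc(Cl)c3)coc2c1` gives only a limit of the assay, > 100000 nM.
- compound 3 `COc1ccc(CNC(=O)/C=C/c2coc3cc(O)ccc3c2=O)cc1` gives 8430 nM.

Compound 3 and compound 1 sit within the scatter of each other; the value of compound 2 is a limit, not a number (the limit of > 100000 nM in this assay, at which 1 of the 3 values shown sits).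

Compound 4 `O=C(/C=C/c1coc2cc(O)ccc2c1=O)NCc1ccccc1` differs from compound 3 by hydrogen in place of methoxy on an aromatic carbon. Among the measured compounds shown here, the only measured step, an at least 6.4-fold higher number from compound 1 to compound 2 (0.80 log units; beyond the scatter), concerns a different change on the anilide ring and does not bear on the benzyl methoxy. For the measured compounds named here, no measured step informs this change, so no shift beyond the scatter is expected in this assay.

The step expected from compound 3 to compound 4 is a 1.2-fold higher number from compound 3 to compound 4 (0.07 log units; within the scatter). Compound 4 is estimated at 10000 nM, with a range from 4000 nM to 30000 nM.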

Compound 4, half-maximal inhibitory concentration: 4690 nM
Compound 4: middle estimate off by 2.1-fold (0.33 log units), on the high side; the measured number falls inside the stated range.
By their numbers in this assay, from the lowest: compounds 4, 3 and 1 (each within the scatter of the next, the first and the last beyond it). At a limit, above all of these: compound 2.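

The pair reads in this assay as a 1.8-fold lower number from compound 3 to compound 4 (0.25 log units; within the scatter) and so the methoxy, para to a large group, can be removed without a shift beyond the scatter. Among the compounds shown here, the earlier step concerned the anilide ring, and this is the sole reading on the benzyl ring. Nothing among the data shown accounts for this step.

Open, going by these compounds, is whether an amine, a carboxylic acid or a longer chain such as ethoxy at this place would stay within the scatter of compound 4. Also open, on these data alone, is whether the chloro-for-methyl step on the anilide ring carries over to the benzyl ring.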